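Azetidinyl in place of hydroxyphenyl on the shared core

This account rests on a few compounds, and the source may have more. Where it says the series, first, only, none or still open, it means among the compounds named here.

Compound 1 `Oc1ccc(CNc2cc(C(F)(F)F)cc3[nH]ncc23)cc1` is the reference point. In an assay for inhibition of Indoleamine 2,3-dioxygenase 1 (Homo sapiens), with stated times of 10 min and 60 min, tested at 100 uM (on this read-out higher numbers stand for a stronger effect at the one concentration tested and lower numbers for a weaker effect), compound 1 gives 81%, the second highest of the three numbers measured. Among the compounds with values here, compound 2 `Oc1ccc(CNc2cc(C(F)(F)F)cc3[nH]ncc23)c(Cl)c1` gives 95% in this assay; the step of a number 14 percentage points higher from compound 1 to compound 2 (beyond the scatter) is the only single-place change measured. Within the data shown here, compound 3 `O=[N+]([O-])c1cccc(CNc2cc(C(F)(F)F)cc3[nH]ncc23)c1` gives 69% in this assay, a lower number than compound 1 and beyond the scatter, though no one-place step is recorded for that pair.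

Compound 4 `FC(F)(F)c1cc(NCC2CNC2)c2cn[nH]c2c1` has not been measured. It differs from compound 1 by azetidin-3-yl in place of 4-hydroxyphenyl on a saturated chain carbon bound to a nitrogen on an aromatic ring. Among the measured compounds shown here, none of the measured steps bears on this change: the step from compound 1 to compound 2 and the pair of compound 1 with compound 3 both keep the six-membered aromatic ring and alter only what sits on it. For the measured compounds named here, for compound 4 the change removes that ring entirely, and the series gives no example of such a replacement. The expectation is therefore a downward step of uncertain size, stated as a wide estimate: for compound 4 the number in this assay is expected to be around 45%, between 15% and 75%. The expected step is a number 36 percentage points lower from compound 1 to compound 4 (beyond the scatter), downward, with low confidence.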

Compound 4, a percentage reported as inhibition, at one concentration (the size of the read-out at that concentration, not a potency): 22%
Beside the measured number, compound 4's estimate is 23 percentage points above it; measured number inside the range.
By their numbers in this assay, from the lowest: compound 4; then compound 3; then compound 1; then compound 2.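

In this assay, within the data shown here, azetidin-3-yl in place of 4-hydroxyphenyl on a saturated chain carbon bound to a nitrogen on an aromatic ring gives a number 59 percentage points lower from compound 1 to compound 4 (beyond the scatter), the first reading at this position in which the six-membered aromatic ring itself is replaced rather than altered. The two groups have the same counts of hydrogen-bond donors and acceptors, so the large step goes with a change that those counts do not register: a four-membered non-aromatic ring with 1 hetero atom enters, the six-membered aromatic ring of carbon only leaves, and the heavy-atom count falls. No measurement at hand accounts for this step.

The change alters ring size, aromatic character and the hetero atom at once, and these remain unseparated; cyclohexyl, piperidin-4-yl and unsubstituted phenyl on the same chain carbon would begin to tell them apart. On these data alone, whether the azetidine ring nitrogen matters also stays open, and an azetidine carrying a methyl group on that nitrogen, or a cyclobutyl group in its place, would address that question.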